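The source may hold more compounds than are shown below. What is called first, only, known or untested is meant among the compounds shown, and "the series" means these compounds.

Measured so far in a functional assay on BJAB cells (Homo sapiens) for antiproliferative activity, with a stated time of 4 days; on this read-out lower numbers stand for an effect already at smaller amounts and higher numbers for an effect only at larger amounts of compound:
compound 1 `Cc1nn(-c2nc(-c3ccc(Cl)c(Cl)c3)c(SC(C)C)s2)c(C(=O)O)c1-c1cnn(C)c1` gives 6800 nM;
compound 2 `Cc1c(-c2cc(Cl)cc(Cl)c2)c(C(=O)O)nn1-c1nc(-c2ccncc2)c(SC(C)C)s1` gives "not active" (no number reported), no number;
compound 3 `Cc1nn(-c2nc(-c3ccc(Cl)c(Cl)c3)c(SC(C)C)s2)c(C(=O)O)c1-c1cc(C(F)(F)F)cc(C(F)(F)F)c1` gives 1800 nM.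

On the two numbers, compound 1 stands highest; compound 3 has the lower number, a gap beyond the scatter. Compound 4 `Cc1nn(-c2nc(-c3ccc(Cl)c(Cl)c3)c(SC(C)C)s2)c(C(=O)O)c1-c1cnccn1` differs from compound 1 by pyrazin-2-yl in place of 1-methyl-1H-pyrazol-4-yl on an aromatic carbon. For the measured compounds named here, both groups are small aromatic rings of the same heavy-atom count, and no measured pair isolates this exchange, so the step from compound 1 is expected to be none beyond the scatter, placing compound 4 close to compound 1. The step expected is a 1.0-fold higher number from compound 1 to compound 4 (0.01 log units; within the scatter). Compound 4 is estimated at 7000 nM in this assay, with a range from 2500 nM to 20000 nM.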

Compound 4, half-maximal effective concentration: 14000 nM
For compound 4 the middle estimate is 2.0-fold (0.30 log units) below the measured one, within the range that was stated.
By their numbers in this assay, from the lowest: compound 3; then compound 1; then compound 4.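

In this assay, for the compounds shown here, pyrazin-2-yl in place of 1-methyl-1H-pyrazol-4-yl gives a 2.1-fold higher number from compound 1 to compound 4 (0.31 log units; beyond the scatter) and so provides the first single-place comparison. This position therefore responds to a six-membered aromatic ring replacing a five-membered one, even with equal counts of heavy atoms and hydrogen-bond acceptors and no net charge. No available evidence bears on this modest step.

The compounds shown leave open how a simple phenyl ring or an aminomethyl group would behave at this position. As far as these compounds go, it also remains open whether this exchange gives a similar step with another group on the shared core.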